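Methoxy in Place of Methylsulfanyl on Compound 3

The compounds below may be only part of what the source reports. "The series", "measured", "known", "first", "only" and "open" are said of these compounds alone.

Of the compounds shown here, three sharing one core have been measured in an assay on isolated protein with Bile acid receptor (Homo sapiens) as the target; a lower number here means that less compound is needed, a higher number that more compound is needed for the effect. Compound 1 `COC(=O)/C=C/c1cccc(N(Cc2ccc(/C=C/c3c(C)cc(C)cc3C)cc2)C(=O)C(C)C)c1` gives 149 nM, compound 2 `COC(=O)/C=C/c1cccc(N(Cc2ccc(/C=C/c3scnc3C)cc2)C(=O)C(C)C)c1` gives 228 nM, and compound 3 `COC(=O)/C=C/c1cccc(N(Cc2ccc(-c3ccc(SC)cc3)cc2)C(=O)C(C)C)c1` gives 51 nM, the lowest of the three numbers. The step of a 2.9-fold lower number from compound 1 to compound 3 (0.47 log units; beyond the scatter) and the step of a 4.5-fold lower number from compound 2 to compound 3 (0.65 log units; beyond the scatter) both favour compound 3, while the step of a 1.5-fold higher number from compound 1 to compound 2 (0.18 log units; within the scatter) stays within the scatter.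

Compound 4 `COC(=O)/C=C/c1cccc(N(Cc2ccc(-c3ccc(OC)cc3)cc2)C(=O)C(C)C)c1` differs from compound 3 in one place: methoxy in place of methylsulfanyl on an aromatic carbon. For the measured compounds named here, none of the measured steps concerns this group; all three alter a different part of the molecule. They therefore say nothing about whether exchanging methylsulfanyl for methoxy moves the number at all. Going by the values given here, with no measured step to lean on, the expectation for compound 4 in this assay is a small shift, none beyond the scatter, expressed as a 1.4-fold higher number from compound 3 to compound 4 (0.14 log units; within the scatter). Compound 4 is thus estimated at 70 nM, with a range expected from 30 nM to 170 nM.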

Compound 4, half-maximal effective concentration: 97 nM
Beside the measured number, compound 4's estimate is 1.4-fold (0.14 log units) below it, and the stated range covers the measured number.
By their numbers in this assay, from the lowest: compounds 3, 4, 1 and 2 (each within the scatter of the next, the first and the last beyond it).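

In this assay, for the compounds shown here, this is the first look at the group para to a large group on the outer ring, and exchanging its sulfur for oxygen gives a 1.9-fold higher number from compound 3 to compound 4 (0.28 log units; within the scatter), so methoxy serves about as well as methylsulfanyl here. The two replacements of the ethenyl-linked groups no longer read alike: a 2.4-fold lower number from compound 2 to compound 4 (0.37 log units; beyond the scatter) still clears the scatter, as the same replacement with methylsulfanyl did, whereas a 1.5-fold lower number from compound 1 to compound 4 (0.19 log units; within the scatter) does not, so the clear separation of compound 3 from compound 1 is not kept with methoxy. Nothing available explains the small difference between the two groups.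

Going by these compounds alone, only two small groups have been compared at this position, so it remains open whether it tolerates a very different one, such as an amine or a carboxylic acid. A longer chain, such as ethoxy, is also an open case.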